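One Ring Group Exchanged on a Shared Core

The compounds below may be only part of what the source reports. "The series", "measured", "known", "first", "only" and "open" are said of these compounds alone.

In a physicochemical assay for lipophilicity, at pH 7.4 (on this read-out lower numbers stand for lower lipophilicity and higher numbers for higher lipophilicity), compound 1 (`Cc1ccc(-n2nc(C(C)(C)C)cc2NC(=O)Nc2cc(-c3ccc4nccnc4c3)[nH]n2)cc1`) gives 4.7 and compound 2 (`CNC(=O)c1cc2cccc(NC(=O)Nc3cc(C(C)(C)C)nn3-c3ccc(C)cc3)c2[nH]1`) gives 4.9 and the two stand level within the usual scatter. Compound 3 (`COc1ccc(-c2cc(NC(=O)Nc3cc(C(C)(C)C)nn3-c3ccc(C)cc3)n[nH]2)cn1`) has not yet been measured. Compared with compound 1, it carries 6-methoxypyridin-3-yl in place of quinoxalin-6-yl on an aromatic carbon. For the measured compounds named here, no measured pair shows this exchange, so the expectation is a loose one. A small upward step is expected, with a number 0.30 log units higher from compound 1 to compound 3 (within the scatter) as the estimate, and it may not clear the scatter. The estimate for compound 3 is 5 in this assay with 4.5 to 5.5 as its expected range.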

Compound 3, distribution coefficient: 4.9
Estimate against measurement, compound 3: 0.10 log units above; the measured number falls inside the stated range.
By their numbers in this assay, from the lowest: compounds 1, 2 and 3 (each within the scatter of the next).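

For the compounds shown here, the first measured exchange at this position of the shared core gives a number 0.20 log units higher from compound 1 to compound 3 (within the scatter) in this assay. So 6-methoxypyridin-3-yl, with one ring and 8 heavy atoms, and quinoxalin-6-yl, with two rings and 10 heavy atoms, stand level on this read-out. Nothing available explains this result.

As far as these compounds go, whether an amine or a carboxylic acid at this position would also stand level remains open. So does the part played by the methoxy group, which only a plain pyridin-3-yl group could separate from the ring that carries it.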